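This account rests on a few compounds, and the source may have more. Where it says the series, first, only, none or still open, it means among the compounds named here.

Measured compounds in a functional assay on HL-60 cells (Homo sapiens) for cytotoxicity, read by WST assay, with a stated time of 48 h; on this read-out higher numbers stand for an effect only at larger amounts of compound and lower numbers for an effect already at smaller amounts:

compound 1 `O=C1OC[C@H](Cc2ccccc2)[C@H]1Cc1cccc(OC(F)(F)F)c1` gives 34000 nM
compound 2 `O=C1OC[C@H](Cc2ccccc2)[C@H]1Cc1ccc(C(F)(F)F)cc1` gives 22000 nM
compound 3 `COc1ccccc1C[C@H]1COC(=O)[C@@H]1Cc1ccc(Cl)c(Cl)c1` gives 14000 nM

All three share the same core and differ in the two aromatic arms. Compound 3 has the lowest number of the three. Against compound 2 the gap is within the scatter, so no order between compound 3 and compound 2 can be read; against compound 1 the gap is beyond the scatter. Compound 3 is therefore not set apart from every other member of the set.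

Compound 4 `O=C1OC[C@H](Cc2ccc(F)cc2)[C@H]1Cc1ccc(Cl)c(Cl)c1` has not yet been measured in this assay. The change from compound 3 is 4-fluorophenyl in place of 2-methoxyphenyl on a saturated chain carbon bound to a saturated ring carbon. The arm bearing the dichlorinated ring is unchanged. Within the data shown here, no measured pair in this set shows a comparable exchange on the other arm, so there is no step to lean on. The expected step from compound 3 to compound 4 is a 1.1-fold higher number from compound 3 to compound 4 (0.03 log units; within the scatter), that is, no change beyond the scatter, with uncertainty in both directions. For compound 4 the estimate in this assay is 15000 nM, within 6000 nM to 40000 nM.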

Compound 4, half-maximal effective concentration: 14000 nM
Beside the measured number, compound 4's estimate is 1.1-fold (0.03 log units) above it; the measured number falls inside the stated range.
By their numbers in this assay, from the lowest: compounds 3, 4, 2 and 1 (each within the scatter of the next, the first and the last beyond it).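

In this assay the exchange of 2-methoxyphenyl for 4-fluorophenyl on a saturated chain carbon bound to a saturated ring carbon shows no change at the digits printed from compound 3 to compound 4 (within the scatter) and gives the series its first step between compounds that differ in one place. With the arm bearing the dichlorinated ring unchanged, this position tolerates the loss of the methoxy oxygen, with its hydrogen-bond acceptor, without a shift in the read-out beyond the scatter. Nothing available speaks to the reason for this result.

The exchange alters both the substituent and its place on the aromatic ring, and these two changes cannot be separated here. Also open, going by these compounds, is whether an amine, a carboxylic acid or a longer chain at this position would leave the read-out equally flat.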